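Adding a third methoxy group to a dimethoxybenzyl triazole

The source may report more compounds than this note shows. Statements on the series, on what has been measured and on what is new or still open speak of the compounds shown alone.

Measured so far:
compound 1, `COc1ccc(Cn2cc(CNC(=O)c3cn(-c4ccccc4)nc3-c3ccc(F)cc3)nn2)cc1`, 3700 nM
compound 2, `COc1ccc(Cn2cc(CNC(=O)c3cn(-c4ccccc4)nc3-c3ccc(F)cc3)nn2)cc1OC`, limit > 100000 nM
compound 3, `COc1cc(Cn2cc(CNC(=O)c3cn(-c4ccccc4)nc3-c3ccc(Cl)cc3)nn2)cc(OC)c1`, 340 nM

All three compounds were tested in a functional assay on MIA PaCa-2 cells (Homo sapiens) for antiproliferative activity, read by sulforhodamine B assay, with a stated time of 48 h; on this read-out higher numbers stand for weaker inhibition of growth and lower numbers for stronger inhibition of growth. Compound 1 gives 3700 nM. Compound 2 reaches only the limit of the assay, > 100000 nM, so no number is known for it; this is the limit of > 100000 nM in this assay, at which 1 of the 3 values shown sits. Compound 3 gives 340 nM, the lowest of the two numbers obtained. The difference between the core of compound 1 and the core of compound 3 is not broken down here.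

Going by the values given here, the one step that can be counted is methoxy in place of hydrogen on an aromatic carbon. In this assay it produced an at least 27-fold higher number from compound 1 to compound 2 (1.43 log units; beyond the scatter), a large change that sends the number past the limit (the limit of > 100000 nM in this assay, at which 1 of the 3 values shown sits).

The unmeasured compound 4, `COc1cc(Cn2cc(CNC(=O)c3cn(-c4ccccc4)nc3-c3ccc(Cl)cc3)nn2)cc(OC)c1OC`, arises from compound 3 by methoxy in place of hydrogen on an aromatic carbon. The surroundings are not identical: in compound 2 the new group sits ortho to a methoxy group and meta to a large group, while in compound 4 it sits ortho to two methoxy groups and para to a large group, so this is the same kind of change rather than the same change. Because the earlier instance gave an at least 27-fold higher number from compound 1 to compound 2 (1.43 log units; beyond the scatter), the step from compound 3 to compound 4 is expected to be an 8.8-fold higher number from compound 3 to compound 4 (0.95 log units; beyond the scatter), with wide uncertainty. Compound 4 is therefore estimated at 3000 nM, between 400 nM and 30000 nM.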

Compound 4, concentration for 50% growth inhibition: 3500 nM
Compound 4: middle estimate off by 1.2-fold (0.07 log units), on the low side; measured number inside the range.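

In this assay, the change from 3,5-dimethoxyphenyl to 3,4,5-trimethoxyphenyl gave a 10-fold higher number from compound 3 to compound 4 (1.01 log units; beyond the scatter), so adding a methoxy group raised the number on both cores, and each rise lies beyond the scatter: the same change on two cores in this assay, an at least 27-fold higher number (1.43 log units; beyond the scatter) from compound 1 to compound 2 and a 10-fold higher number (1.01 log units; beyond the scatter) from compound 3 to compound 4; the limit leaves it open whether they differ

The value of compound 2, > 100000 nM, is a limit and not a number: the limit of > 100000 nM in this assay, at which 1 of the 4 values shown sits.

On these data alone, the direction of the change therefore carried over from one core to the other, but the true size of the step on the core of compound 1 remains unknown, and two cores cannot show that the same direction would hold on any further core.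

The compounds shown leave open whether a different group on the same ring carbon, such as an ethoxy group, a hydroxyl group or an amine, would give a number different from that of the methoxy group in compound 4. They also leave open what number the 3,4,5-trimethoxyphenyl group would give with the fluorine of compound 1 in place of the chlorine of compound 4.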